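A Chain Extension Measured Only Against Limits

The source may report more compounds than this note shows. Statements on the series, on what has been measured and on what is new or still open speak of the compounds shown alone.

In a functional assay on KB cells (Homo sapiens) for inhibition, read by CellTiter-Blue, with a stated time of 96 h, in the presence of a further agent that is not named here (on this read-out lower numbers stand for stronger inhibition and higher numbers for weaker inhibition), compound 1 `Nc1nc2[nH]c(CCCCCCC(=O)O)cc2c(=O)[nH]1` gives > 1000 nM, which is a limit of the assay and not a number. Compound 2 `Nc1nc2[nH]c(CCCCCCCC(=O)O)cc2c(=O)[nH]1` gives > 1000 nM, again a limit and not a number. That is all that can be said of where compound 2 stands: the limit of > 1000 nM in this assay, at which 2 of the 2 values shown sit. Compound 3 `Nc1nc2[nH]c(CCCCCCCCC(=O)O)cc2c(=O)[nH]1` differs from compound 2 as follows: carboxymethyl in place of carboxy on a saturated chain carbon, seven bonds along the chain from an aromatic carbon. In short, carboxymethyl replaces carboxy on a saturated chain carbon, seven bonds along the chain from an aromatic carbon. Among the measured compounds shown here, the only measured step that bears on this is the same replacement made six bonds along the chain, a step that the two limits leave unreadable from compound 1 to compound 2. It offers no size or direction to carry over, so no change beyond the scatter is expected, and another limit is the likeliest report. The expected step is a step that the limit leaves unreadable from compound 2 to compound 3. For compound 3 the estimate is 2500 nM, with an expected range from 1000 nM to 10000 nM.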

Compound 3, half-maximal inhibitory concentration: > 1000 nM
Compound 3: only a limit was reported (the forecaster's own chance of this, stated with the estimate: 85%); the middle value lies beyond the limit too.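

In this assay, among the compounds shown here, compound 3 also gives only a limit and not a number, so no step among compound 1, compound 2 and compound 3 can be read: the limit of > 1000 nM in this assay, at which 3 of the 3 values shown sit. Going by these compounds, how strongly any of these three compounds inhibits, and whether the longer chain changes that, remains open.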